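A few compounds are considered here, and "the series" means these few. Any claim that something is new, unique, unknown or untested is made for them only; others in the source may bear on it.

Measured so far in an assay on isolated protein for inhibition of adenosine deaminase (Bos taurus), with a stated time of 5 min; on this read-out higher numbers stand for weaker inhibition and lower numbers for stronger inhibition: compound 1, `C[C@H](O)[C@@H](CCc1cccc(Br)c1)n1cnc2c(N)ncnc21`, gives 0.6 nM; compound 2, `C[C@H](O)[C@@H](CCc1cccc(C(=O)O)c1)n1cnc2c(N)ncnc21`, gives 53 nM.

Compound 2 stands highest of the two numbers in this assay; its nearest neighbour is compound 1, separated by an 88-fold higher number from compound 1 to compound 2 (1.95 log units; beyond the scatter). Compound 3, `C[C@H](O)[C@@H](CCc1cccc(C(=O)N2CCCC2)c1)n1cnc2c(N)ncnc21`, is not yet measured and differs from compound 2 by pyrrolidin-1-yl in place of hydroxy on a carbonyl carbon. Going by the values given here, no measured step shares this change. Among the compounds with values here, the only step known, an 88-fold higher number from compound 1 to compound 2 (1.95 log units; beyond the scatter), concerns introducing the carboxy group, so the present edit acts on the very group behind that large rise; some reversal is expected, of uncertain size. For compound 3 the estimate is 6 nM, range 1 nM to 35 nM, an expected step of an 8.8-fold lower number from compound 2 to compound 3 (0.95 log units; beyond the scatter).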

Compound 3, inhibition constant: 2.2 nM
The estimate for compound 3 lay 2.7-fold (0.44 log units) above the measured number, and the stated range covers the measured number.
By their numbers in this assay, from the lowest: compound 1; then compound 3; then compound 2.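

In this assay, replacing the hydroxy of the carboxy group with pyrrolidin-1-yl gives a 24-fold lower number from compound 2 to compound 3 (1.38 log units; beyond the scatter) and so wins back most of the earlier rise. The step of a 3.7-fold higher number from compound 1 to compound 3 (0.56 log units; beyond the scatter) leaves only a modest gap to the bromo group, so the large loss seen with carboxy does not extend to every carbonyl substituent at this aromatic carbon. No measurement available here accounts for either step. From the compounds shown here alone, whether the ring itself matters remains open: a dimethylamide or a primary amide would separate it from the carbonyl, and an aminomethyl group would test the carbonyl's role.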